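The source may hold more compounds than are shown below. What is called first, only, known or untested is meant among the compounds shown, and "the series" means these compounds.

Measured so far:
Compound 1, `O=C(Nc1cccc(-n2cc(-c3ccncc3)c(-c3ccc(Cl)c(O)c3)n2)c1)Nc1cccc(C(F)(F)F)c1`, 4110 nM
Compound 2, `COc1cc(-c2nn(-c3cccc(NC(=O)Nc4ccc(Cl)c(Cl)c4)c3)cc2-c2ccncc2)ccc1Cl`, 1430 nM

Of the compounds shown here, two have been measured in a functional assay on SK-MEL-28 cells (Homo sapiens) for inhibition, read by sulforhodamine B assay, with a stated time of 48 h; a higher number here means a weaker inhibitor of growth, a lower number a stronger inhibitor of growth. Compound 2 gives the lower of the two numbers, 1430 nM; the nearest value is that of compound 1, 4110 nM, a gap that lies beyond the usual scatter of this assay. Compound 2 is therefore the stronger growth inhibitor of the pair.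

Compound 3, `O=C(Nc1cccc(-n2cc(-c3ccncc3)c(-c3ccc(Cl)c(O)c3)n2)c1)Nc1ccc(Cl)c(Cl)c1`, has not yet been measured. It differs from compound 2 in a single place: hydrogen in place of methyl on an oxygen on an aromatic ring, so that a methoxy becomes a hydroxy and the 4-chloro-3-methoxyphenyl becomes a 4-chloro-3-hydroxyphenyl. Going by the values given here, no measured pair shows this exact change, so there is no step to lean on for its size or direction. The change is small and the rest of compound 2 is kept, so the step from compound 2 to compound 3 in this assay is expected to be modest, a 1.1-fold higher number from compound 2 to compound 3 (0.05 log units; within the scatter), possibly within the scatter. Compound 3 is estimated at 1600 nM, in the range 500 nM to 4500 nM.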

Compound 3, concentration for 50% growth inhibition: 1460 nM
For compound 3 the middle estimate is 1.1-fold (0.04 log units) above the measured one, and the stated range covers the measured number.
By their numbers in this assay, from the lowest: compounds 2 and 3 (each within the scatter of the next); then compound 1.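

In this assay, replacing the methyl on the oxygen with hydrogen, which turns the methoxy into a hydroxy, gives a 1.0-fold higher number from compound 2 to compound 3 (0.01 log units; within the scatter), so this read-out does not separate the 4-chloro-3-methoxyphenyl from the 4-chloro-3-hydroxyphenyl when the rest of the molecule stays the same. Going by these compounds alone, the second step keeps the 4-chloro-3-hydroxyphenyl and puts 3,4-dichlorophenyl in place of 3-(trifluoromethyl)phenyl on an amide-type nitrogen, giving a 2.8-fold lower number from compound 1 to compound 3 (0.45 log units; beyond the scatter), which is the first single-place comparison to show a change beyond the scatter and locates a real difference at that nitrogen's substituent rather than at the oxygen. No measurement available here speaks to why the oxygen change leaves the number in place or why the change at the nitrogen moves it.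

The compounds shown carry only hydrogen or methyl on that oxygen, so it remains open how an ethyl group, a longer chain or a chain ending in an amine would behave there. Going by these compounds, it also remains open whether methoxy and hydroxy would still match with the 3-(trifluoromethyl)phenyl in place.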